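The source may report more compounds than this note shows. Statements on the series, on what has been measured and on what is new or still open speak of the compounds shown alone.

Measured compounds:

- compound 1, `Nc1ncnc2c1nc(NCCCCNC(=O)CI)n2[C@@H]1O[C@H](COP(=O)(O)OP(=O)(O)OP(=O)(O)O)[C@@H](O)[C@H]1O`; in an assay on isolated protein for inhibition of hexokinase-3 (Rattus norvegicus), with a stated time of 6 h, tested at 10 mM (on this read-out lower numbers stand for less inhibition and higher numbers for more inhibition at the one concentration tested (going by the name of the read-out)), compound 1 gives 0%
- compound 2, `O=C(CI)NCCCCCCC(=O)NCCCCCCNc1ncnc2c1ncn2[C@@H]1O[C@H](COP(=O)(O)OP(=O)(O)OP(=O)(O)O)[C@@H](O)[C@H]1O`; in this assay compound 2 gives 0%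
- compound 3, `O=C(CI)NCCCCCC(=O)NCCCNc1ncnc2c1ncn2[C@@H]1O[C@H](COP(=O)(O)OP(=O)(O)OP(=O)(O)O)[C@@H](O)[C@H]1O`; in this assay compound 3 gives 0%

All three measured compounds share the same triphosphate-bearing core and carry an iodoacetamide on a linker of varying length. In this assay, for the measured compounds named here, compound 2 stands level with compound 1 and with compound 3 at the digits reported; no difference between any pair of them reaches beyond the usual scatter, so no ordering among them can be drawn from these numbers. Going by the values given here, no step between measured compounds differing in a single place is available.

Compound 4, `O=C(I)NCC(=O)NCCCCCCNc1ncnc2c1ncn2[C@@H]1O[C@H](COP(=O)(O)OP(=O)(O)OP(=O)(O)O)[C@@H](O)[C@H]1O`, is not yet measured. It differs from compound 2 as follows: a group of 4 heavy atoms (1 carbon, 1 nitrogen, 1 oxygen, 1 iodine; no ring) in place of a group of 10 heavy atoms (7 carbon, 1 nitrogen, 1 oxygen, 1 iodine; no ring), on a saturated chain carbon bound to a carbonyl carbon. The change shortens the linker between the core and the iodine-bearing terminus, with the iodine now attached directly to the carbonyl carbon.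

Since compound 1, compound 2 and compound 3 all give the same read-out regardless of linker length, no step beyond the scatter is expected from compound 2 to compound 4 in this assay; the expected step is no change at the digits printed from compound 2 to compound 4 (within the scatter). In this assay compound 4 is estimated at 0%, within a range from 0% to 10%.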

Compound 4, a percentage reported as inhibition, at one concentration (the size of the read-out at that concentration, not a potency): 0%
Compound 4: middle estimate and measured number agree at the digits printed; low and high end bracket the measured number.
By their numbers in this assay, from the lowest: compounds 1, 2, 3 and 4 (each within the scatter of the next).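

In this assay, replacing the 5-(((iodomethyl)carbonyl)amino)pentyl group with the group of 4 heavy atoms, on a saturated chain carbon bound to a carbonyl carbon, gives no change at the digits printed from compound 2 to compound 4 (within the scatter). For the compounds shown here, this is the first step that changes one place only, and it shows that this read-out does not separate the two groups at this position, since compound 4 gives 0% and so adds no read-out different from those of the earlier compounds. No measured evidence on the cause of this result is at hand.

On these data alone, what a carboxylic acid or an amine would give in place of the 5-(((iodomethyl)carbonyl)amino)pentyl group stays open, as does the outcome for a chain longer than that pentyl. With no compound shown at a value other than that of compound 4, it also stays open whether any change at this position can move the read-out of this assay at all.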